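A Chloro-Trifluoromethyl Swap at the Assay Limit

The compounds below may be only part of what the source reports. "The series", "measured", "known", "first", "only" and "open" are said of these compounds alone.

In a functional assay on U-87MG ATCC cells for antiproliferative activity against U-87 MG (Homo sapiens), read by spectrophotometry, with a stated time of 2 days (on this read-out higher numbers stand for weaker inhibition of growth and lower numbers for stronger inhibition of growth), compound 1 (`Cc1cc(Cl)ccc1Nc1ncc(C(F)(F)F)c(N2Cc3cccc(N(C)S(C)(=O)=O)c3C2)n1`) gives 28300 nM. Compound 2 (`CN(c1cccc2c1CN(c1nc(Nc3ccc(Cl)c(C(F)(F)F)c3)ncc1C(F)(F)F)C2)S(C)(=O)=O`) gives > 30000 nM, which is a limit of the assay and not a number. Compound 2 therefore stands at the limit of > 30000 nM in this assay, at which 1 of the 2 values shown sits.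

Compound 3 (`CN(c1cccc2c1CN(c1nc(Nc3cc(Cl)cc(C(F)(F)F)c3)ncc1C(F)(F)F)C2)S(C)(=O)=O`) keeps the shared core of compound 2 and alters only the substituted phenyl group: 3-chloro-5-(trifluoromethyl)phenyl in place of 4-chloro-3-(trifluoromethyl)phenyl on a nitrogen on an aromatic ring. In words, 3-chloro-5-(trifluoromethyl)phenyl stands in place of 4-chloro-3-(trifluoromethyl)phenyl on a nitrogen on an aromatic ring, with the same atoms joined differently.

Within the data shown here, one measured step bears on this change, made at the same place: an at least 1.0-fold higher number from compound 1 to compound 2 (0.02 log units; that floor lies within the scatter). That step is only a floor, so it gives no measured size for a change of this kind. Among the measured compounds shown here, the expectation rests on that step and on compound 1 at 28300 nM, the only number available.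

The estimated step is a number no higher from compound 2 to compound 3 (the limit leaves the size open), so no step beyond the scatter is expected in this assay, and another limit is quite likely. For compound 3 the expected value is 30000 nM, with an estimated range from 12000 nM to 75000 nM.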

Compound 3, concentration for 50% growth inhibition: 5500 nM
For compound 3 the middle estimate is 5.5-fold (0.74 log units) above the measured one, outside the stated range (below it).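

On a nitrogen on an aromatic ring, 3-chloro-5-(trifluoromethyl)phenyl in place of 4-chloro-3-(trifluoromethyl)phenyl, with the same atoms joined differently, gives an at least 5.4-fold lower number from compound 2 to compound 3 (0.73 log units; beyond the scatter) in this assay. That size is only a floor, because the value of compound 2 is a limit of the assay and not a number: the limit of > 30000 nM in this assay, at which 1 of the 3 values shown sits. The replacement of 4-chloro-2-methylphenyl at the same place gives a 5.1-fold lower number from compound 1 to compound 3 (0.71 log units; beyond the scatter), so this position, where the earlier step showed nothing beyond the scatter, does respond to which substituted phenyl group it carries, and here to where the chloro and trifluoromethyl groups stand on it.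

The three compounds do not tell whether the stronger inhibition of growth depends on the chloro group, the trifluoromethyl group or the two together, and a phenyl group with a nitrile or a carboxylic acid in place of the trifluoromethyl would test that. On these data alone, whether the step from this change holds on other cells, or on a core other than the shared one, also stays open.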